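A few compounds are considered here, and "the series" means these few. Any claim that something is new, unique, unknown or untested is made for them only; others in the source may bear on it.

Working notes on the series. In an assay on isolated protein for binding affinity to stress-70 protein, mitochondrial (Homo sapiens) (on this read-out lower numbers stand for tighter binding and higher numbers for weaker binding), compound 2 `CN1c2ccc(NC(=O)Nc3ccc([N+](=O)[O-])cc3)cc2C(C)(C)C(=O)C1(C)C` gives 300 nM, compound 3 `CN1c2ccc(NC(=O)Nc3ccc(C(F)(F)F)cc3)cc2C(C)(C)C(=O)C1(C)C` gives 1500 nM, and compound 1 `CC1(C)CCNc2ccc(NC(=S)Nc3ccc([N+](=O)[O-])cc3)cc21` gives 1600 nM. Within the data shown here, compound 3 stands second highest of these three numbers; its value and that of compound 1 lie within the scatter of each other, while the one measured step shows a 5.0-fold higher number from compound 2 to compound 3 (0.70 log units; beyond the scatter). Compound 4 `CN1c2ccc(NC(=O)Nc3ccc(OC(F)(F)F)cc3)cc2C(C)(C)C(=O)C1(C)C` carries trifluoromethoxy in place of trifluoromethyl on an aromatic carbon. Among the measured compounds shown here, no measured step covers this exchange: the only step known concerns a nitro group and does not touch a trifluoromethoxy, so no direction can be read from it. In this assay the expected step is therefore none beyond the scatter, no change at the digits printed from compound 3 to compound 4 (within the scatter). Compound 4 is expected to give 1500 nM in this assay, with a range of 600 nM to 4000 nM.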

Compound 4, dissociation constant: 1800 nM
Estimate against measurement, compound 4: 1.2-fold (0.08 log units) below, and the stated range covers the measured number.
By their numbers in this assay, from the lowest: compound 2; then compounds 3, 1 and 4 (each within the scatter of the next).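

In this assay, trifluoromethoxy in place of trifluoromethyl on the aromatic carbon para to a large group gives a 1.2-fold higher number from compound 3 to compound 4 (0.08 log units; within the scatter), so the two fluorinated groups cannot be told apart at this position. Against nitro, the same group gives a 6.0-fold higher number from compound 2 to compound 4 (0.78 log units; beyond the scatter), so on this core nitro now stands apart from both fluorinated groups, not only from trifluoromethyl. Nothing available bears on the reason for this difference.

On these data alone, whether nitro stands alone at this position remains open, since a nitrile or an amine there would test how far the separation extends.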